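The source may hold more compounds than are shown below. What is called first, only, known or untested is meant among the compounds shown, and "the series" means these compounds.

Compound 1 `CC1=C(SCCCO)C(=O)c2ccccc2C1=O`: 4850 nM
Compound 2 `CC1=C(SCCCCO)C(=O)c2ccccc2C1=O`: 4510 nM
Compound 3 `CC1=C(SCCCCCCO)C(=O)c2ccccc2C1=O`: > 10000 nM (a limit of the assay)

All three were tested in a functional assay on SW480 cells (Homo sapiens) for inhibition; on this read-out higher numbers stand for weaker inhibition and lower numbers for stronger inhibition. Compound 1 gives 4850 nM and compound 2 gives 4510 nM, so that a 1.1-fold lower number from compound 1 to compound 2 (0.03 log units; within the scatter). For compound 3 the result is > 10000 nM, which is a limit of the assay and not a number. Compound 3 therefore stands at the weak end of the three, since an at least 2.0-fold higher number from compound 1 to compound 3 (0.31 log units; beyond the scatter) and an at least 2.2-fold higher number from compound 2 to compound 3 (0.34 log units; beyond the scatter).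

Compound 4 `CC1=C(SC(C)C(C)O)C(=O)c2ccccc2C1=O` has not yet been measured. It differs from compound 3 in one place: 2-hydroxy-1-methylpropyl in place of 6-hydroxyhexyl on a sulfur. The measured steps that bear on this change are the two chain lengthenings toward compound 3, both of which raised the number in this assay beyond the scatter. Compound 4 carries a shorter chain, nearer in length to those of compound 1 and compound 2, so the number is expected to move back down toward theirs. The branching on the chain has no measured counterpart among these compounds, which leaves the estimate wide.

Compound 4 is thus expected to show an at least 2.0-fold lower number from compound 3 to compound 4 (0.30 log units; that floor lies within the scatter). Compound 4 is estimated at 5000 nM, with a likely range from 2000 nM to 15000 nM.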

Compound 4, half-maximal inhibitory concentration: 5530 nM
Compound 4: the middle estimate sits 1.1-fold (0.04 log units) below what was measured, within the range that was stated.
By their numbers in this assay, from the lowest: compounds 2, 1 and 4 (each within the scatter of the next). At a limit, above all of these: compound 3.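

In this assay, the 2-hydroxy-1-methylpropyl group on the sulfur shows that this position accepts a branched chain as well as the straight ones, with a 1.1-fold higher number from compound 1 to compound 4 (0.06 log units; within the scatter) and a 1.2-fold higher number from compound 2 to compound 4 (0.09 log units; within the scatter). Set against the 6-hydroxyhexyl group, the same change gives an at least 1.8-fold lower number from compound 3 to compound 4 (0.25 log units; that floor lies within the scatter). That step is only a floor, since compound 3 stands at a limit of the assay: the limit of > 10000 nM in this assay, at which 1 of the 4 values shown sits.

The compounds shown keep a hydroxy group on every chain, so it remains open whether an amine or a carboxylic acid in its place would give a similar number in this assay. As far as these compounds go, it is also open whether a chain with no hydroxy group at all, such as a plain butyl, would match these values.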